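A few compounds are considered here, and "the series" means these few. Any claim that something is new, unique, unknown or untested is made for them only; others in the source may bear on it.

Compound 1 `CC1(C)[C@H]2CC[C@]1(C)N(Cc1cn(-c3cccc(F)c3)nn1)C(=O)C2`: 180 nM
Compound 2 `CC1(C)[C@H]2CC[C@]1(C)N(Cc1cn(-c3ccccc3C#N)nn1)C(=O)C2`: 100 nM
Compound 3 `CC1(C)[C@H]2CC[C@]1(C)N(Cc1cn(-c3ccc(Br)cc3)nn1)C(=O)C2`: 80 nM

These three compounds share one core and differ only in the aryl group on the triazole-type ring, and all were tested in a functional assay on A549 cells (Homo sapiens) for inhibition, read by MTT assay, with a stated time of 24 h; on this read-out lower numbers stand for stronger inhibition and higher numbers for weaker inhibition. Compound 3, at 80 nM, sits within the scatter of compound 2, as shown by a 1.3-fold lower number from compound 2 to compound 3 (0.10 log units; within the scatter). Its separation from compound 1 is modest but beyond the scatter, at a 2.3-fold lower number from compound 1 to compound 3 (0.35 log units; beyond the scatter).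

Compound 4 `CC1(C)[C@H]2CC[C@]1(C)N(Cc1cn(-c3cccc(O)c3)nn1)C(=O)C2` has not yet been measured. It differs from compound 3 as follows: 3-hydroxyphenyl in place of 4-bromophenyl on an aromatic nitrogen. This places 3-hydroxyphenyl in place of 4-bromophenyl on an aromatic nitrogen.

Among the measured compounds shown here, no measured compound carries this group, so the evidence is indirect. The closest guide is compound 1, whose 3-fluorophenyl group gives the largest measured step, a 2.3-fold lower number from compound 1 to compound 3 (0.35 log units; beyond the scatter). The other aryl exchanges, a 1.8-fold lower number from compound 1 to compound 2 (0.26 log units; within the scatter) and a 1.3-fold lower number from compound 2 to compound 3 (0.10 log units; within the scatter), stay within the scatter. Across these compounds, aryl exchanges have therefore moved the number only slightly, and a small rise in this assay is expected, towards weaker inhibition. The estimated step is a 1.9-fold higher number from compound 3 to compound 4 (0.27 log units; within the scatter). For compound 4 the estimated value is 150 nM, with an expected range from 60 nM to 380 nM.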

Compound 4, half-maximal inhibitory concentration: 180 nM
Beside the measured number, compound 4's estimate is 1.2-fold (0.08 log units) below it, and the stated range covers the measured number.
By their numbers in this assay, from the lowest: compounds 3, 2, 1 and 4 (each within the scatter of the next, the first and the last beyond it).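

In this assay, 3-hydroxyphenyl brings a hydrogen-bond donor and acceptor that 4-bromophenyl lacks, and this exchange gives a 2.3-fold higher number from compound 3 to compound 4 (0.35 log units; beyond the scatter), so a second aryl group now stands modestly apart from 4-bromophenyl. Hydroxy in place of fluoro on the aromatic carbon gives no change at the digits printed from compound 1 to compound 4 (within the scatter), and 3-hydroxyphenyl in place of 2-cyanophenyl gives a 1.8-fold higher number from compound 2 to compound 4 (0.26 log units; within the scatter), so the two 3-substituted phenyl groups read alike, while 2-cyanophenyl cannot be separated from either of them or from 4-bromophenyl. Nothing shown here accounts for this outcome at the aryl position.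

The step between 4-bromophenyl and 3-hydroxyphenyl changes both the substituent and its place on the phenyl ring, so the compounds shown do not tell which of the two matters; 3-bromophenyl and 4-hydroxyphenyl would separate them. Going by these compounds, it also remains open whether an amine, a methoxy group or a carboxylic acid on the same phenyl ring would stay within this narrow span of values or move outside it.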